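The compounds below may be only part of what the source reports. "The series", "measured", "known", "first", "only" and "open" are said of these compounds alone.

Working notes on the series. In a functional assay on K562 cells (Homo sapiens) for inhibition, read by trypan blue exclusion, with a stated time of 72 h (a lower number here means a stronger inhibitor, a higher number a weaker inhibitor), compound 2 (`Cn1c(=O)c(S(=O)(=O)c2ccc(F)cc2F)cc2cnc(Nc3ccncn3)nc21`) gives 30000 nM, at the weak end of the measured set. Compound 3 (`Cc1ccc(S(=O)(=O)c2cc3cnc(Nc4cnc5[nH]ccc5c4)nc3n(C)c2=O)cc1`) at 15000 nM lies within the scatter of that value, while compound 1 (`CN1CCN(c2ccc(Nc3ncc4cc(S(=O)(=O)c5ccc(F)cc5F)c(=O)n(C)c4n3)cc2)CC1`) at 5000 nM is a lower number, beyond the scatter.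

The next compound is compound 4 (`Cn1c(=O)c(S(=O)(=O)c2ccc(F)cc2F)cc2cnc(NCc3ccc4[nH]ccc4c3)nc21`), not yet measured. It carries (1H-indol-5-yl)methyl in place of pyrimidin-4-yl on a nitrogen on an aromatic ring.

Within the data shown here, no measured pair isolates this change, so the support is thin. Among the measured compounds shown here, the only pointer is that compound 1, with another group on that nitrogen, reaches 5000 nM. Compound 3 goes against any general gain, as its 15000 nM stays within the scatter of compound 2.

In this assay, a modest move towards a lower number is expected, and the estimated size is a 3.0-fold lower number from compound 2 to compound 4 (0.48 log units; beyond the scatter). That step may not clear the scatter by much, and no change at all would not be surprising. For compound 4 the estimated value is 10000 nM, with an expected range of 3000 nM to 30000 nM.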

Compound 4, half-maximal inhibitory concentration: 75000 nM
For compound 4 the middle estimate is 7.5-fold (0.88 log units) below the measured one, outside the stated range (above it).
By their numbers in this assay, from the lowest: compound 1; then compounds 3 and 2 (each within the scatter of the next); then compound 4.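

In this assay, among these compounds, the step between compound 2 and compound 4 is the first to isolate a change on this nitrogen, and the change gives a 2.5-fold higher number from compound 2 to compound 4 (0.40 log units; beyond the scatter). The number at this position can therefore move up as well as down, while compound 1, with its own group on the same nitrogen, stands at 5000 nM; a gain is thus not general to replacing pyrimidin-4-yl, and a larger group with a hydrogen-bond donor does not bring one here. No measurement in hand accounts for this step.

The change replaces the ring and also adds a methyl link between the nitrogen and the new ring system, and the compounds shown do not separate these two parts. A 1H-indol-5-yl group set directly on that nitrogen, or a plain benzyl group there, would show whether the higher number goes with the link or with the indole, and whether either one matters on its own.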